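Adding a bromo group to compound 3

A few compounds are considered here, and "the series" means these few. Any claim that something is new, unique, unknown or untested is made for them only; others in the source may bear on it.

Compound 1 `COc1ccc(C(=O)n2c(-c3cn(C)c4ccccc34)nc3ccccc32)cc1` gives 10400 nM
Compound 2 `COc1ccc(C(=O)n2c(-c3cn(C)c4ccccc34)nc3ccccc32)cc1OC` gives 3100 nM
Compound 3 `Cn1cc(-c2nc3ccccc3n2C(=O)c2cccc(Br)c2)c2ccccc21` gives 34200 nM

All three values come from a functional assay on A549 cells (Homo sapiens) for inhibition, read by MTT assay, with a stated time of 24 h; on this read-out higher numbers stand for weaker inhibition of growth and lower numbers for stronger inhibition of growth. Compound 3 has the highest number of the three, 34200 nM, so it holds back growth the least. Compound 4 `Cn1cc(-c2nc3ccccc3n2C(=O)c2cccc(Br)c2)c2cc(Br)ccc21` differs from compound 3 in one place: bromo in place of hydrogen on an aromatic carbon. In words, this is bromo in place of hydrogen on an aromatic carbon.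

For the measured compounds named here, no measured step makes this exact change. The closest is also a swap of hydrogen on an aromatic carbon, but with methoxy and elsewhere in the molecule: a 3.4-fold lower number from compound 1 to compound 2 (0.53 log units; beyond the scatter), a modest step. The steps of a 3.3-fold higher number from compound 1 to compound 3 (0.52 log units; beyond the scatter) and an 11-fold higher number from compound 2 to compound 3 (1.04 log units; beyond the scatter) replace a whole group on the carbonyl carbon, so they say little here. The weak precedent points to a modest drop in this assay that may stay within the scatter. The expected change is a 1.9-fold lower number from compound 3 to compound 4 (0.28 log units; within the scatter). For compound 4 the estimated value is 18000 nM, with an expected range from 5000 nM to 50000 nM.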

Compound 4, concentration for 50% growth inhibition: 38500 nM
Estimate against measurement, compound 4: 2.1-fold (0.33 log units) below; the measured number falls inside the stated range.
By their numbers in this assay, from the lowest: compound 2; then compound 1; then compounds 3 and 4 (each within the scatter of the next).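

In this assay the bromo in place of hydrogen on this aromatic carbon, meta to a fused ring and para to a fused ring, gives a 1.1-fold higher number from compound 3 to compound 4 (0.05 log units; within the scatter) and so stays within the scatter: here, with 3-bromophenyl on the carbonyl carbon, bromo and hydrogen cannot be told apart. The earlier steps all changed the group on the carbonyl carbon, and each lay beyond the scatter, as with a 3.4-fold lower number from compound 1 to compound 2 (0.53 log units; beyond the scatter) for an added methoxy, so this is the only change shown on the other side of the molecule. Nothing shown here offers an explanation for this result.

Going by these compounds, whether an amine or a carboxylic acid on this same aromatic carbon would move the number remains open. So does whether bromo here would read the same with 3,4-dimethoxyphenyl on the carbonyl carbon.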